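The source may report more compounds than this note shows. Statements on the series, on what has been measured and on what is new or still open speak of the compounds shown alone.

Compound 1 `O=C(O)c1cccn1-c1ccc2c(c1)B(O)OC2`: > 10 ug/mL
Compound 2 `CCCNC(=O)c1cccn1-c1ccc2c(c1)B(O)OC2`: > 10 ug/mL

Compound 2 stands at a limit: in an ADME assay on L929 cells (Mus musculus) for cytotoxicity, read by resazurin assay, with a stated time of 72 h (a lower number here means a stronger inhibitor, a higher number a weaker inhibitor), compound 2 gives > 10 ug/mL, which is a limit of the assay rather than a number. Compound 1 likewise gives > 10 ug/mL, again a limit. The step that the two limits leave unreadable from compound 1 to compound 2 is therefore unreadable, both values sitting at the limit of > 10 ug/mL in this assay, at which 2 of the 2 values shown sit. Compound 3 `O=C(NC1CCCCC1)c1cccn1-c1ccc2c(c1)B(O)OC2` carries cyclohexyl in place of propyl on an amide-type nitrogen. For the measured compounds named here, no measured step bears readably on this change, so nothing points to a readable shift. Compound 3 is thus expected to give 15 ug/mL, in the range 5 ug/mL to 50 ug/mL. The step that the limit leaves unreadable from compound 2 to compound 3 is expected to stay within the scatter.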

Compound 3, half-maximal inhibitory concentration: > 10 ug/mL
Compound 3 was reported as a limit; the forecaster's own chance of this, stated with the estimate: 75%; the middle value does not contradict the limit.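

No step can be read among compound 1, compound 2 and compound 3, since each result is a limit and not a number: the limit of > 10 ug/mL in this assay, at which 3 of the 3 values shown sit.

Going by these compounds, what stays open is how the propylamino, cyclohexylamino and hydroxy groups on the carbonyl carbon compare in this assay once actual numbers are available.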